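Ester variation at the thiophene carboxylate of compound 3

A few compounds are considered here, and "the series" means these few. Any claim that something is new, unique, unknown or untested is made for them only; others in the source may bear on it.

Measured compounds in an assay on isolated protein for inhibition of protein kinase C zeta type (Homo sapiens), with stated times of 1 h and 2.5 min, tested at 30 uM; on this read-out higher numbers stand for more inhibition at the one concentration tested (going by the name of the read-out) and lower numbers for less inhibition:
compound 1 `CCOC(=O)c1cscc1-c1ccc(OC)c(OC)c1` gives 3%
compound 2 `CCOC(=O)c1c(-c2ccc(OC)c(OC)c2)csc1N(C)C` gives 60%
compound 3 `COCC(C)OC(=O)c1c(-c2ccc(OC)c(OC)c2)csc1N` gives 49%

Compound 3 stands second highest of the three numbers in this assay. Its nearest neighbour is compound 2, which lies higher by an amount beyond the scatter; compound 1 lies much lower. Among the compounds with values here, the only step between measured compounds that differ in one place is a number 57 percentage points higher from compound 1 to compound 2 (beyond the scatter), dimethylamino in place of hydrogen on an aromatic carbon. It does not touch the ester portion.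

Compound 4 `COc1ccc(-c2csc(N)c2C(=O)OCc2ccncc2)cc1OC` is the next compound. It differs from compound 3 by (pyridin-4-yl)methyl in place of 1-(methoxymethyl)ethyl on an oxygen next to a carbonyl group. None of the measured steps changes the group on the oxygen next to the carbonyl in isolation, so no measured step bears on this change; compounds 1 and 2 carry a different ester from compound 3 but also differ elsewhere, and their values show only what is given above. With no guidance from the series, the expectation for compound 4 is a step of a number 2 percentage points lower from compound 3 to compound 4 (within the scatter), that is, none beyond the scatter. Compound 4 is therefore estimated at 47% in this assay, with a range from 25% to 70%.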

Compound 4, a percentage reported as inhibition, at one concentration (the size of the read-out at that concentration, not a potency): 53%
Compound 4: middle estimate off by 6 percentage points, on the low side, within the range that was stated.
By their numbers in this assay, from the lowest: compound 1; then compounds 3, 4 and 2 (each within the scatter of the next, the first and the last beyond it).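

In this assay the only difference between the two compounds lies in the group on an oxygen next to a carbonyl group, and the step is a number 4 percentage points higher from compound 3 to compound 4 (within the scatter) with the rest of the structure held constant. Within the data shown here, this is the first comparison that isolates this position, and it shows that the read-out does not separate (pyridin-4-yl)methyl from 1-(methoxymethyl)ethyl, although the entering group carries a six-membered aromatic ring with 1 hetero atom and the leaving group has no ring. No measurement at hand offers an explanation for this result.

Still open, on these data alone, is whether a carboxylic acid or a primary amide in place of the ester would stay in the same range in this read-out, and whether a plain benzyl group on the same oxygen would read like (pyridin-4-yl)methyl. Also open, as far as these compounds go, is how a dimethylamino group compares with the amino group of compound 3 and compound 4 on a shared ester, since compound 2 differs from each of them in two places.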